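This account rests on a few compounds, and the source may have more. Where it says the series, first, only, none or still open, it means among the compounds named here.

Three compounds share one core, a dimethyl-substituted aromatic ring bearing a ketone that carries a cyclopentylmethyl group, linked through a four-carbon chain of two ether oxygens to a second aromatic ring that carries a carboxylic acid. Compound 1 `Cc1c(OCCCCOc2ccccc2C(=O)O)ccc(C(=O)CC2CCCC2)c1C` has that acid next to the chain's attachment. In an assay on HEK293 cells for positive allosteric modulation of metabotropic glutamate receptor 2 (Rattus norvegicus), read by thallium flux, with a stated time of 2.5 min (a higher number here means that more compound is needed for the effect, a lower number that less compound is needed), compound 1 gives 2580 nM. Compound 2 `Cc1c(OCCCCOc2ccc(C(=O)O)cc2)ccc(C(=O)CC2CCCC2)c1C` moves the acid to the opposite side of the ring; in this assay compound 2 is recorded as "not determined" (no result reported), so compound 2 stands without a number, and the effect of moving the acid cannot be read from these data.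

Compound 3 `Cc1c(OCCCCOc2ccc(C(=O)O)c(Cl)c2)ccc(C(=O)CC2CCCC2)c1C` differs from compound 2 in one place: chloro in place of hydrogen on an aromatic carbon. The change adds a single chlorine on an aromatic carbon, ortho to a carboxy group and meta to a large group.

Among the compounds with values here, since compound 2 has no value and no measured pair shows this change, the size and direction of its step in this assay cannot be judged beyond an open guess. Within the data shown here, the only anchor is compound 1, whose value is 2580 nM, a weak effect. Compound 3 is expected to land in a similar region, around 3500 nM, with an estimated range from 700 nM to 17000 nM, and a real chance that only a limit is reported.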

Compound 3, half-maximal effective concentration: 2420 nM
Estimate against measurement, compound 3: 1.4-fold (0.16 log units) above, within the range that was stated.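

Compound 3 gives this series a second firm number, and the comparison in this assay shows a 1.1-fold lower number from compound 1 to compound 3 (0.03 log units; within the scatter) so the 4-carboxy-3-chlorophenyl group and the 2-carboxyphenyl group read alike here. A carboxy group with a chloro ortho to it, on the ring that compound 3 carries, is therefore compatible with a measurable effect of the same weak order as that of compound 1. The step from hydrogen to chloro itself cannot be read, as compound 2 has no number, and nothing shown explains the result.

On these data alone, it stays open how much of the reading of compound 3 belongs to the chloro and how much to the place of the carboxy group, a question that only a number for compound 2 would settle. Also open, as far as these compounds go, is whether a fluoro or a methyl on the same aromatic carbon, or a longer chain between the two ether oxygens, would move the number beyond the usual scatter.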